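Furan-2-yl in Place of Benzyl: Cytotoxicity Expected to Stay Flat

A few compounds are considered here, and "the series" means these few. Any claim that something is new, unique, unknown or untested is made for them only; others in the source may bear on it.

compound 1 `O=C(Nc1cccc(Cc2ccccc2)c1)C1CCCN(C(=O)c2cc(C(F)(F)F)cc(C(F)(F)F)c2)C1` — 0%
compound 2 `O=C(c1ccccc1)c1cccc(C(=O)N2CCCC(C(=O)Nc3ccc(Cl)cc3)C2)c1` — 0%
compound 3 `O=C(Nc1ccc(Cl)cc1)C1CCCN(C(=O)c2cccc(-c3cnco3)c2)C1` — 0%

Three compounds sharing one core have been run in an ADME assay on PC-3 cells (Homo sapiens) for cytotoxicity, read by WST assay, tested at 100 uM (a lower number here means less inhibition, a higher number more inhibition at the concentration tested (going by the name of the read-out)), and compound 1 gives 0% there. Compound 2 and compound 3 sit at the same level, so compound 1 stands level with both of them, within the scatter of the read-out. Among the compounds with values here, the one measured step, no change at the digits printed from compound 2 to compound 3 (within the scatter), swapped 1,3-oxazol-5-yl in place of benzoyl on an aromatic carbon and moved nothing beyond the scatter.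

Compound 4 `O=C(Nc1cccc(-c2ccco2)c1)C1CCCN(C(=O)c2cc(C(F)(F)F)cc(C(F)(F)F)c2)C1` is the next analogue of compound 1. The change is furan-2-yl in place of benzyl on an aromatic carbon. Within the data shown here, no measured step alters that same position, so the only guide is the measured step, which changed an aromatic substituent elsewhere on the core without any shift in inhibition. Given that, and given that all three measured compounds cluster at the same level, the step from compound 1 to compound 4 is expected to be a number 2 percentage points higher from compound 1 to compound 4 (within the scatter), that is, none beyond the scatter. For compound 4 the estimated value is therefore 2%, with a range from 0% to 12%.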

Compound 4, a percentage reported as inhibition, at one concentration (the size of the read-out at that concentration, not a potency): 0%
Compound 4: middle estimate off by 2 percentage points, on the high side, within the range that was stated.
By their numbers in this assay, from the lowest: compounds 1, 2, 3 and 4 (each within the scatter of the next).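

In this assay, within the data shown here, the first measured step at this position reads no change at the digits printed from compound 1 to compound 4 (within the scatter) with furan-2-yl in place of benzyl on an aromatic carbon, meta to a large group. The earlier step concerned a different part of the molecule, whereas this one shows that the read-out also holds when a six-membered aromatic ring of carbon only gives way here to a five-membered aromatic ring with 1 hetero atom, bringing in 1 hydrogen-bond acceptor. No separate measurement is available to explain this result.

Going by these compounds, whether an amine or a carboxylic acid on the same aromatic carbon would also leave this assay unmoved remains open. All the compounds shown print the same value there, with compound 4 at 0%, and they do not show which change to the shared core, if any, would produce a step beyond the scatter.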